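A few compounds are considered here, and "the series" means these few. Any claim that something is new, unique, unknown or untested is made for them only; others in the source may bear on it.

In an ADME assay on microsomes from liver (Mus musculus, strain CD-1) for metabolic stability, read by LC-MS, using NADPH, with a stated time of 60 min, tested at 1 uM (on this read-out lower numbers stand for a shorter-lived compound and higher numbers for a longer-lived compound), compound 2 `Cc1cc([N+](=O)[O-])ccc1-c1ccc(CN2CCCC2c2cccc(N(C)C)c2)o1` gives 0.07 h as its half-life. Compound 3 `O=[N+]([O-])c1ccccc1-c1ccc(CN2CCCC2c2ccc(N3CCCC3)cc2)o1` gives 0.0445 h, a number within the scatter of that of compound 2. Compound 1 `CN(C)c1cccc(C2CCCN2Cc2ccc(-c3ccccc3[N+](=O)[O-])o2)c1` gives 0.013 h on the same read-out, and the gap between this number and that of compound 2 exceeds the scatter.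

Compound 4 `Cc1cc([N+](=O)[O-])ccc1-c1ccc(CN2CCCC2c2ccc(N(C)C)cc2)o1` differs from compound 2 at one place, with 4-(dimethylamino)phenyl in place of 3-(dimethylamino)phenyl on a saturated ring carbon, next to the ring nitrogen 4-(dimethylamino)phenyl in place of 3-(dimethylamino)phenyl on a saturated ring carbon in the counted terms.

Among the compounds with values here, no measured step changes this group. Within the data shown here, the only measured step, a 5.4-fold higher number from compound 1 to compound 2 (0.73 log units; beyond the scatter) as a modest change, concerns 2-methyl-4-nitrophenyl in place of 2-nitrophenyl on an aromatic carbon. Compound 4 already carries that group, so this step gives no direction here.

No step beyond the scatter is therefore expected in this assay for this change. The expected step is a 1.1-fold higher number from compound 2 to compound 4 (0.06 log units; within the scatter) on this basis. For compound 4 the estimated half-life is 0.08 h with an expected range of 0.035 h to 0.18 h in this series.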

Compound 4, half-life: 0.0607 h
The estimate for compound 4 lay 1.3-fold (0.12 log units) above the measured number, and the stated range covers the measured number.
By their numbers in this assay, from the lowest: compound 1; then compounds 3, 4 and 2 (each within the scatter of the next).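

Working with the 2-methyl-4-nitrophenyl group held fixed, the shift from 3-(dimethylamino)phenyl to 4-(dimethylamino)phenyl on the saturated ring carbon gives a 1.2-fold lower number from compound 2 to compound 4 (0.06 log units; within the scatter) in this assay. Within the data shown here, this is the first measured change at this place, since the only earlier step concerned the aromatic group at the other end of the molecule. On this pair, the half-life does not separate the two placements of the dimethylamino group, and no measurement at hand bears on why the two read alike.

From the compounds shown here alone, it remains open whether the same change reads alike with 2-nitrophenyl in place of 2-methyl-4-nitrophenyl. Also open, going by these compounds, is whether a morpholine or a methoxy group in place of the dimethylamino group would shift the half-life beyond the scatter.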